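Compound 1 to compound 4: adding isopentylcarbamoyl

The source may report more compounds than this note shows. Statements on the series, on what has been measured and on what is new or still open speak of the compounds shown alone.

In a physicochemical assay for solubility (a lower number here means a less soluble compound, a higher number a more soluble compound), compound 1 (`CNC(=O)c1cccn(Cc2ccccc2)c1=O`) gives 78 ug/mL and compound 2 (`CNC(=O)c1cc(C(=O)NC2CC2)cn(Cc2nccc3[nH]ccc23)c1=O`) gives 73 ug/mL, two values within the scatter of each other. Compound 3 (`CNC(=O)c1cc(C(=O)NC2CC2)cn(Cc2cccc3cn[nH]c23)c1=O`) gives >= 181 ug/mL, which is a limit of the assay and not a number.

Compound 4 (`CNC(=O)c1cc(C(=O)NCCC(C)C)cn(Cc2ccccc2)c1=O`) carries isopentylcarbamoyl in place of hydrogen on an aromatic carbon.

Among the measured compounds shown here, the only measured step, an at least 2.4-fold higher number from compound 2 to compound 3 (0.39 log units; beyond the scatter), lies beyond the scatter, but it exchanges one group on a saturated chain carbon bound to an aromatic nitrogen for another. It therefore does not test the present change and gives only a rough idea of how far this assay can move within the series. For the measured compounds named here, no measured step adds an isopentylcarbamoyl group, so this expectation is a judgement from the structural change, starting at compound 1 with 78 ug/mL. The expected change is a 3.9-fold lower number from compound 1 to compound 4 (0.59 log units; beyond the scatter), toward a lower number and with wide uncertainty. For compound 4 the estimated value is 20 ug/mL, with an expected range of 4 ug/mL to 70 ug/mL.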

Compound 4, solubility: 10 ug/mL
Compound 4: middle estimate off by 2.0-fold (0.30 log units), on the high side; measured number inside the range.
By their numbers in this assay, from the lowest: compound 4; then compounds 2 and 1 (each within the scatter of the next). At a limit, above all of these: compound 3.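

In this assay, isopentylcarbamoyl in place of hydrogen on an aromatic carbon, two atoms from the ring nitrogen, gives a 7.8-fold lower number from compound 1 to compound 4 (0.89 log units; beyond the scatter), so a single addition at this position moves the number beyond the scatter. Among the compounds shown here, the only earlier step exchanged a group on a saturated chain carbon bound to an aromatic nitrogen, so it gave no reading at this aromatic carbon. No evidence shown here bears on the reason for this fall.

From the compounds shown here alone, whether a shorter chain, or a longer chain ending in an amine or a carboxylic acid, would move the number as far from the same position remains open. Also open, going by these compounds, is whether the isopentylcarbamoyl step would be of similar size with a group other than benzyl on the ring nitrogen.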